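The compounds below may be only part of what the source reports. "The series", "measured", "known", "first", "only" and "open" are said of these compounds alone.

Compound 1, `COc1ccc(C(=O)/C=C/c2ccc(N(C)C)cc2)c2c1C=CC(C)(C)O2`: 1870 nM
Compound 2, `COc1ccc(C(=O)/C=C/c2ccc(OC)c(OC)c2OC)c2c1C=CC(C)(C)O2`: > 10000 nM

Both measured compounds were tested in a functional assay on HT-29 cells (Homo sapiens) for antiproliferative activity, read by MTT assay, with a stated time of 24 h; on this read-out lower numbers stand for stronger inhibition and higher numbers for weaker inhibition. Among the compounds with values here, compound 1 gives 1870 nM, and this is the only number in the set. For compound 2 the assay reports only a limit, > 10000 nM, and that is what the limit of > 10000 nM in this assay, at which 1 of the 2 values shown sits, records. Within the data shown here, no two measured compounds differ in a single place, so no measured step can be drawn between them, and the two values can only be set side by side: one number and one limit.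

Compound 3, `COc1ccc(C(=O)/C=C/c2ccccc2Cl)c2c1C=CC(C)(C)O2`, has not yet been measured. It differs from compound 1 in one place: 2-chlorophenyl in place of 4-(dimethylamino)phenyl on a double-bonded chain carbon bound to a double-bonded chain carbon. The shared core and the double-bonded chain stay as they are; only the aromatic ring at the end of the chain is exchanged.

With nothing measured on this exchange, the expectation rests on the values shown. The expected step is a weakening in this assay, somewhat beyond the usual scatter, a 2.4-fold higher number from compound 1 to compound 3 (0.38 log units; beyond the scatter). Compound 3 is therefore estimated at about 4500 nM in this assay, with a range from 1500 nM to 10000 nM.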

Compound 3, half-maximal inhibitory concentration: > 10000 nM
Compound 3 ended at the assay's limit; the forecaster's own chance of this, stated with the estimate: 30%; at least 2.2-fold (0.34 log units) between middle value and limit.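

Within the data shown here, exchanging 4-(dimethylamino)phenyl for 2-chlorophenyl on a double-bonded chain carbon bound to a double-bonded chain carbon gives the first step that can be read in this set: in this assay the change brings an at least 5.3-fold higher number from compound 1 to compound 3 (0.72 log units; beyond the scatter). From the compounds shown here alone, this shows that the aromatic ring at the end of the chain matters for this read-out, with the shared core left as it is, although the full size of the step stays unknown, as the result for compound 3 is a limit of the assay and not a number. Compound 1 is still the only one of the three with a number, and the other two stop at the same limit: the limit of > 10000 nM in this assay, at which 2 of the 3 values shown sit.

This single exchange removes the dimethylamino group and adds the chlorine at once, so the compounds shown leave open which of the two accounts for the weaker result. Going by these compounds, a plain phenyl ring at this place would help to separate the two, and how a ring carrying a carboxylic acid would behave in this assay also remains open.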